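The compounds below may be only part of what the source reports. "The series", "measured", "known", "first", "only" and "open" are said of these compounds alone.

Compound 1 `N=C(N)c1ccc(-c2ccc(-c3cncc4ccccc34)s2)s1` and compound 2 `N=C(N)c1ccc(-c2ccc(-c3ccc(F)cc3)o2)o1` are the two measured compounds here. In a functional assay on HT-29 cells (Homo sapiens) for inhibition, read by sulforhodamine B assay, with a stated time of 48 h (a lower number here means a stronger inhibitor of growth, a higher number a weaker inhibitor of growth), compound 1 gives 560 nM, and in this assay compound 2 gives 610 nM. Compound 2 sits at the upper of these two values, but its gap from compound 1 lies within the scatter, so the two cannot be told apart. Compound 3 `N=C(N)c1ccc(-c2ccc(-c3ccc(Cl)cc3)o2)o1` differs from compound 2 in one place: chloro in place of fluoro on an aromatic carbon. Going by the values given here, no measured pair shows this exchange, so the step expected in this assay is small, within the scatter, with no clear direction. Compound 3 is therefore estimated at 500 nM, in a range from 250 nM to 1200 nM. For compound 3 this estimate means an expected step of a 1.2-fold lower number from compound 2 to compound 3 (0.09 log units; within the scatter).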

Compound 3, concentration for 50% growth inhibition: 1680 nM
Compound 3: the middle estimate sits 3.4-fold (0.53 log units) below what was measured; the whole stated range lies below it.
By their numbers in this assay, from the lowest: compounds 1 and 2 (each within the scatter of the next); then compound 3.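

Exchanging fluoro for chloro on this aromatic carbon, para to a large group, is not a neutral swap in this assay: the change gives a 2.8-fold higher number from compound 2 to compound 3 (0.44 log units; beyond the scatter) and so a weaker inhibitor of growth. Going by these compounds alone, this is the first sign that growth inhibition here depends on which halogen occupies this position. No measurement at hand explains the step.

The compounds shown leave open how a bromo, a methoxy or an amine at this place would compare. They also leave open whether the same exchange would act similarly on another core, such as the core of compound 1.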